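The compounds below may be only part of what the source reports. "The series", "measured", "known", "first", "only" and "open" are said of these compounds alone.

Compound 1 `c1ccc2c(c1)CN[C@@H](CN(CCC1CCNCC1)[C@H]1CCCc3cccnc31)C2` is the weaker of the two measured compounds in a functional assay on CCRF-CEM cells for antagonist activity at C-X-C chemokine receptor type 4 (Homo sapiens), read by calcium flux, with stated times of 25 min and 90 s (a higher number here means a weaker inhibitor, a lower number a stronger inhibitor), where compound 1 gives 150 nM. Compound 2 `c1cnc2c(c1)CCC[C@@H]2N(CCCN1CCNCC1)Cc1cc2ccccc2cn1` in this assay gives 17 nM, a gap beyond the usual scatter, though the two structures differ in more than one place. Compound 3 `NC(=O)N1CCN(CCCN(C[C@H]2Cc3ccccc3CN2)[C@H]2CCCc3cccnc32)CC1` carries (4-carbamoylpiperazin-1-yl)methyl in place of piperidin-4-yl on a saturated chain carbon, two bonds along the chain from an amine nitrogen. Compound 2 also bears a piperazine on a three-carbon chain from the amine nitrogen, which suggests this direction may be favourable. The step of a 2.5-fold lower number from compound 1 to compound 3 (0.40 log units; beyond the scatter) is therefore expected to be a modest gain, and compound 3 is estimated at 60 nM, within a range of 20 nM to 200 nM.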

Compound 3, half-maximal inhibitory concentration: 959 nM
For compound 3 the middle estimate is 16-fold (1.20 log units) below the measured one, and the stated range ends below it.
By their numbers in this assay, from the lowest: compound 2; then compound 1; then compound 3.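

In this assay, the position on a saturated chain carbon, two bonds along the chain from an amine nitrogen, proves sensitive to the group it carries: (4-carbamoylpiperazin-1-yl)methyl in place of piperidin-4-yl gives a 6.4-fold higher number from compound 1 to compound 3 (0.81 log units; beyond the scatter). The swap therefore loses potency, although the entering group keeps a six-membered non-aromatic ring and no net charge. No available measurement accounts for this loss. Among these compounds, the single step changes the ring and adds the carbamoyl group together, so their shares remain unresolved. Open, from the compounds shown here alone, is whether piperazin-1-ylmethyl, without the carbamoyl group, would stand nearer compound 1 or compound 3.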